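The source may report more compounds than this note shows. Statements on the series, on what has been measured and on what is new or still open speak of the compounds shown alone.

The series rests on one shared core, carried by compound 1 `COc1ccc(C(=O)Nc2ccc(Cl)cn2)cc1Nc1nccc(-c2cccnc2)n1`, compound 2 `COc1ccc(C(=O)Nc2ccncc2)cc1Nc1nccc(-c2cccnc2)n1`, compound 3 `COc1ccc(C(=O)Nc2ccc(F)c(Cl)c2)cc1Nc1nccc(-c2cccnc2)n1` and compound 4 `COc1ccc(C(=O)Nc2cccc(Cl)c2)cc1Nc1nccc(-c2cccnc2)n1`, the members differing only in the group attached to the amide nitrogen. Among the measured compounds shown here, in a functional assay on K562 cells (Homo sapiens) for antiproliferative activity, read by MTT assay, with a stated time of 48 h (on this read-out higher numbers stand for weaker inhibition and lower numbers for stronger inhibition), compound 2 gives 94500 nM, and that is the only number in hand. For compound 1 the record in this assay reads "not determined" (no result reported), and for compound 3 it likewise reads "not determined" (no result reported), so compound 3 stands without a number of its own and without a measured neighbour from which a step could be drawn. The move from compound 3 to compound 4 is small: hydrogen in place of fluoro on an aromatic carbon. For the measured compounds named here, no measured pair shows what such a change does here, and no direction can be read from the data; a shift beyond the scatter is not expected either way, but nothing in hand rules one out. Taking compound 2 as the only anchor, compound 4 is expected to give about 60000 nM in this assay, within a wide range from 10000 nM to 200000 nM.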

Compound 4, half-maximal inhibitory concentration: 237000 nM
Beside the measured number, compound 4's estimate is 4.0-fold (0.60 log units) below it; measured number above the stated range.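

In this assay the group on the amide nitrogen now has a step that can be read (a 2.5-fold higher number from compound 2 to compound 4 (0.40 log units; beyond the scatter)), with 3-chlorophenyl in place of pyridin-4-yl, so this position is not indifferent to the group it carries, and of the two groups with numbers, 3-chlorophenyl goes with the weaker inhibition. The steps that involve compound 1 or compound 3 cannot be read, so the loss of fluoro on its own remains without a measured effect. No measured finding at hand explains the direction of the step between compound 2 and compound 4.

From the compounds shown here alone, what fluoro alone does at this aromatic carbon stays open. So does whether an amine or a carboxylic acid in place of the chloro group, or a longer chain in place of the aromatic ring on the amide nitrogen, would move the number in either direction.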